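Urea restored on the trifluoromethyl aryl arm

The compounds below may be only part of what the source reports. "The series", "measured", "known", "first", "only" and "open" are said of these compounds alone.

For the measured compounds named here, compound 2 `COc1cc(-c2nn(-c3cccc(NC(=O)c4ccc(Cl)c(C(F)(F)F)c4)c3)cc2-c2ccncc2)ccc1Cl` stands at the higher of the two numbers measured so far, giving 2790 nM in a functional assay on M14 cells (Homo sapiens) for inhibition, read by sulforhodamine B assay, with a stated time of 48 h (a lower number here means a stronger inhibitor of growth, a higher number a weaker inhibitor of growth), while compound 1 `COc1cc(-c2nn(-c3cccc(NC(=O)Nc4ccc(Cl)c(Cl)c4)c3)cc2-c2ccncc2)ccc1Cl` gives 911 nM. Compound 3 `COc1cc(-c2nn(-c3cccc(NC(=O)Nc4ccc(Cl)c(C(F)(F)F)c4)c3)cc2-c2ccncc2)ccc1Cl` differs from compound 2 by (4-chloro-3-(trifluoromethyl)phenyl)amino in place of 4-chloro-3-(trifluoromethyl)phenyl on a carbonyl carbon. Going by the values given here, the one measured step that bears on this change is the urea-to-amide exchange on the same arm, a 3.1-fold higher number from compound 1 to compound 2 (0.49 log units; beyond the scatter), and compound 3 undoes that exchange while keeping the chloro-trifluoromethyl aryl group. A step of comparable size in the opposite direction is therefore expected, a 2.9-fold lower number from compound 2 to compound 3 (0.47 log units; beyond the scatter). Compound 3 is estimated at 950 nM, within a range of 400 nM to 2300 nM.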

Compound 3, concentration for 50% growth inhibition: 1080 nM
Estimate against measurement, compound 3: 1.1-fold (0.06 log units) below; measured number inside the range.
By their numbers in this assay, from the lowest: compounds 1 and 3 (each within the scatter of the next); then compound 2.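

In this assay, a 2.6-fold lower number from compound 2 to compound 3 (0.41 log units; beyond the scatter) isolates the change to the amino link on the carbonyl carbon, whereas the earlier amide-urea comparison also changed the aryl substituent. With the urea kept, a 1.2-fold higher number from compound 1 to compound 3 (0.07 log units; within the scatter) shows that trifluoromethyl in place of chloro on an aromatic carbon gives no separable difference between these two compounds. No evidence on the origin of either step is available.

Still open, as far as these compounds go, is how a methyl group on the urea nitrogen would compare with the hydrogen present in compound 3. Also open, from the compounds shown here alone, is how an amine or a carboxylic acid would compare with the trifluoromethyl on this aryl arm.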